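Lengthening the amide chain of compound 1

The source may report more compounds than this note shows. Statements on the series, on what has been measured and on what is new or still open speak of the compounds shown alone.

In a functional assay on MCF7 cells (Homo sapiens) for inhibition (a lower number here means a stronger inhibitor, a higher number a weaker inhibitor), compound 1 (`CCCCCCNC(=O)c1cc(NCc2cc(O)ccc2O)ccc1O`) gives 11000 nM and compound 2 (`O=C(NCc1ccccc1)c1cc(NCc2cc(O)ccc2O)ccc1O`) gives 17000 nM, so these two numbers cannot be separated. Compound 3 (`CCCCCCCCCCCCNC(=O)c1cc(NCc2cc(O)ccc2O)ccc1O`) differs from compound 1 by hexyl in place of hydrogen on a saturated chain carbon, six bonds along the chain from an amide-type nitrogen. Within the data shown here, the only measured step, a 1.5-fold higher number from compound 1 to compound 2 (0.19 log units; within the scatter), is phenyl in place of pentyl, so it bears only loosely on this change, and no measured step tests chain length directly. No step beyond the scatter is expected in this assay, and the estimated step is a 1.4-fold lower number from compound 1 to compound 3 (0.14 log units; within the scatter). For compound 3 the estimated value is 8000 nM, with an expected range of 2500 nM to 22000 nM.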

Compound 3, half-maximal inhibitory concentration: 1000 nM
Compound 3: middle estimate off by 8.0-fold (0.90 log units), on the high side; the whole stated range lies above it.
By their numbers in this assay, from the lowest: compound 3; then compounds 1 and 2 (each within the scatter of the next).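

In this assay the amide chain is not silent: the measured change gives an 11-fold lower number from compound 1 to compound 3 (1.04 log units; beyond the scatter) with hexyl in place of hydrogen on a saturated chain carbon, six bonds along the chain from an amide-type nitrogen. The earlier pair, whose step lay within the scatter, gave no sign of a change of this size at this chain. Going by these compounds, whether a longer chain than that of compound 3 lowers the number further remains open, as does the effect of a carboxylic acid or an amine on the chain. No measured evidence bears on the reason for this step.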